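Aryl ester in place of a succinate on a triterpenoid core

This account rests on a few compounds, and the source may have more. Where it says the series, first, only, none or still open, it means among the compounds named here.

Measured compounds:
Compound 1 `CC1=CC[C@H]2[C@H](CC[C@]2(C)O)C(C)(C)[C@@H]1CC[C@H]1[C@]2(C)CC[C@H](OC(=O)CCC(=O)O)C(C)(C)O[C@H]2CC[C@@]1(C)O` — 27900 nM
Compound 2 `CC(=O)O[C@H]1CC[C@]2(C)[C@H](CC[C@@](C)(O)[C@H]2CC[C@@H]2C(C)=CC[C@@H]3C(C)=CC[C@@H]3C2(C)C)OC1(C)C` — 39200 nM
Compound 3 `CC1=CC[C@H]2[C@H](CC[C@]2(C)O)C(C)(C)[C@@H]1CC[C@H]1[C@]2(C)CC/C(=N/OC(=O)c3ccccc3)C(C)(C)O[C@H]2CC[C@@]1(C)O` — 27400 nM

Of the compounds shown here, three sharing one core have been tested in a functional assay on MDA-MB-231 cells (Homo sapiens) for antiproliferative activity, read by MTT assay, with a stated time of 72 h; a higher number here means a weaker inhibitor, a lower number a stronger inhibitor. Compound 1 gives 27900 nM, the second highest of the three numbers. Its nearest neighbour is compound 3, which gives 27400 nM, a difference within the scatter of the method. The furthest is compound 2, which gives 39200 nM, also within the scatter. No order can be read among these three; they behave as one cluster.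

Compound 4 `CC1=CC[C@H]2[C@H](CC[C@]2(C)O)C(C)(C)[C@@H]1CC[C@H]1[C@]2(C)CC[C@H](OC(=O)c3ccc(C(F)(F)F)cc3F)C(C)(C)O[C@H]2CC[C@@]1(C)O` has not yet been measured. It differs from compound 1 in one place:

2-fluoro-4-(trifluoromethyl)phenyl in place of 2-carboxyethyl on a carbonyl carbon

Among the measured compounds shown here, no step between two measured compounds touches this position, so the size of the change cannot be read from the data. The three measured compounds carry different groups at the same region of the core yet sit together, which argues for a modest effect here. The step from compound 1 to compound 4 is expected to be small, a 1.4-fold lower number from compound 1 to compound 4 (0.14 log units; within the scatter), toward a somewhat lower number but likely not beyond the scatter. Compound 4 is therefore estimated at 20000 nM, within a range from 7000 nM to 60000 nM.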

Compound 4, half-maximal inhibitory concentration: 36300 nM
Estimate against measurement, compound 4: 1.8-fold (0.26 log units) below, within the range that was stated.
By their numbers in this assay, from the lowest: compounds 3, 1, 4 and 2 (each within the scatter of the next).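

In this assay, among the compounds shown here, the exchange of 2-carboxyethyl for 2-fluoro-4-(trifluoromethyl)phenyl on a carbonyl carbon gives a 1.3-fold higher number from compound 1 to compound 4 (0.11 log units; within the scatter) and this is the first step at this position that can be read at all. The two groups have little in common: a chain with no ring and with a hydrogen-bond donor leaves, and a six-membered aromatic ring of carbon only, with no hydrogen-bond donor or acceptor, enters. Even so, compound 1 and compound 4 are not separated in this read-out, so at this position the exchange of these two groups leaves no effect that can be told from the scatter, and nothing here accounts for that result.

Because only this one exchange can be read at the position, the compounds shown cannot tell whether the carboxyl end of the chain, the aromatic ring or its fluorine-bearing substituents matter on their own. They also leave open whether an amine or a longer chain ending in a carboxylic acid, placed on the same carbonyl carbon of the shared core, would give a step beyond the scatter.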